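This account rests on a few compounds, and the source may have more. Where it says the series, first, only, none or still open, it means among the compounds named here.

Measured in a functional assay on RAW264.7 cells (Mus musculus) for inhibition, read by Griess assay, with a stated time of 24 h; on this read-out lower numbers stand for stronger inhibition and higher numbers for weaker inhibition:
- compound 1 `COc1cccc(/C=C/C(=O)c2c(OC)cc(OC)cc2OC(C)=O)c1`: 3600 nM
- compound 2 `COc1cccc(/C=C/C(=O)c2ccc(OC)cc2O)c1`: 3200 nM

Only these two numbers exist so far, and they lie within the scatter of each other. Going by the values given here, compound 2 therefore stands level with compound 1 in this assay, and no single-change step between measured compounds is available.

The next compound to be read is compound 3 `COc1cccc(/C=C/C(=O)c2c(O)cc(OC)cc2OC)c1`. It derives from compound 2 with methoxy in place of hydrogen on an aromatic carbon, ortho to a large group (methoxy in place of hydrogen on an aromatic carbon).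

Nothing measured shows what this change does, so the expectation rests on the two values alone. Compound 1 at 3600 nM and compound 2 at 3200 nM give no sign of a steep response in this series, though two compounds are thin evidence. No step beyond the scatter is expected, with only a slight lean towards a lower number. The expected step is a 1.1-fold lower number from compound 2 to compound 3 (0.06 log units; within the scatter). For compound 3 the estimated value is 2800 nM, with an expected range of 1000 nM to 8000 nM.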

Compound 3, half-maximal inhibitory concentration: 2400 nM
The estimate for compound 3 lay 1.2-fold (0.07 log units) above the measured number; low and high end bracket the measured number.
By their numbers in this assay, from the lowest: compounds 3, 2 and 1 (each within the scatter of the next).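

In this assay, going by these compounds alone, methoxy in place of hydrogen on an aromatic carbon, ortho to a large group, gives a 1.3-fold lower number from compound 2 to compound 3 (0.12 log units; within the scatter) and is the first reading of a change at this position; in these two compounds the added methoxy leaves the number level with that of the hydrogen. The second comparison concerns an oxygen on the aromatic ring, where hydrogen in place of acetyl gives a 1.5-fold lower number from compound 1 to compound 3 (0.18 log units; within the scatter) and so the free hydroxy of compound 3 and the acetyl form of compound 1 also stand level. No measurement in hand accounts for either result.

At the aromatic carbon only hydrogen and methoxy are shown, so it stays open whether an amine, a carboxylic acid or a longer chain such as butoxy would also leave the number within the scatter. On the oxygen only hydrogen and acetyl are shown, and a longer acyl chain such as butanoyl would test whether the level reading extends beyond these two groups.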